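Methyl added to a side chain: what happens next

This account rests on a few compounds, and the source may have more. Where it says the series, first, only, none or still open, it means among the compounds named here.

Measured so far in a functional assay on the whole organism with Rattus norvegicus as the target, at a dose of 3 mg/kg by the oral route; a higher number here means a stronger effect of the compound at the dose given, a lower number a weaker effect:
compound 1, `CCCc1ccc(-c2cc(OC)cc(C(=O)Nc3nn[nH]n3)n2)cc1`, gives 93%.
compound 2, `CCCCc1ccc(-c2cc(OC)cc(C(=O)Nc3nn[nH]n3)n2)cc1`, gives 61%.
compound 3, `CCCc1cc(C(=O)Nc2nn[nH]n2)nc(-c2ccc(C)cc2)c1`, gives 50%.

Compound 1 and compound 2 share a core and differ in one place: methyl in place of hydrogen on a saturated chain carbon, three bonds along the chain from an aromatic carbon. That step read a number 32 percentage points lower from compound 1 to compound 2 (beyond the scatter), a loss well beyond the usual scatter. Compound 3 stands lowest of the three; the difference between its core and that of compound 1 is not broken down here, so its value can only be set beside the others. Compound 4, `Cc1ccc(-c2cc(CC(C)C)cc(C(=O)Nc3nn[nH]n3)n2)cc1`, is not yet measured in this assay. It differs from compound 3 in a similar way: methyl in place of hydrogen on a saturated chain carbon bound to two saturated chain carbons. Here the carbon that takes the new methyl is bound to two saturated chain carbons, whereas from compound 1 to compound 2 it lay three bonds along the chain from an aromatic carbon, so this is the same kind of change rather than the same one. The expected step from compound 3 to compound 4 is a number 20 percentage points lower from compound 3 to compound 4 (beyond the scatter), smaller than the earlier loss but in the same direction. Among the measured compounds shown here, this rests on the one earlier example of the change, a number 32 percentage points lower from compound 1 to compound 2 (beyond the scatter). Compound 4 is therefore estimated at 30%, likely between 10% and 55%.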

Compound 4, a percentage reported as inhibition, in the whole organism at one dose (the size of the read-out at that dose, not a potency): 52%
Beside the measured number, compound 4's estimate is 22 percentage points below it; measured number inside the range.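

In this assay, the methyl that enters on a saturated chain carbon bound to two saturated chain carbons gives a number 2 percentage points higher from compound 3 to compound 4 (within the scatter), so this core shows no measurable change. The same kind of change therefore does not carry a fixed effect from one core to the other: the same change on two cores in this assay, a number 32 percentage points lower (beyond the scatter) from compound 1 to compound 2 and a number 2 percentage points higher (within the scatter) from compound 3 to compound 4, 34 percentage points apart, beyond the scatter of two such steps. This does not show why the two steps part, since the carbon that takes the methyl also differs between the two cases, and two examples, each read at a single dose, give no rule for a further core.

The compounds shown leave open how a longer chain, an amine or a carboxylic acid in place of the new methyl would read on either core. They also leave open whether the methyl would give a similar step on each core if it entered on the same kind of carbon, which would separate the role of the core from that of the place.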